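This account rests on a few compounds, and the source may have more. Where it says the series, first, only, none or still open, it means among the compounds named here.

Measured compounds:
compound 1 `CC(=O)N1c2ccccc2CCC1C(=O)Nc1ccccc1O` gives 50700 nM;
compound 2 `O=C(Nc1ccccc1O)C1CCc2ccccc2N1C(=O)c1ccc(Cl)cc1` gives 19600 nM;
compound 3 `O=C(Nc1ccccc1C(F)(F)F)C1CCc2ccccc2N1C(=O)c1ccccc1` gives 8090 nM.

All three were tested in a functional assay on ACHN cells (Homo sapiens) for cytotoxicity, read by sulforhodamine B assay, with a stated time of 72 h; a higher number here means a weaker inhibitor of growth, a lower number a stronger inhibitor of growth. On these numbers compound 3 stands lowest of the three, that is, as the strongest growth inhibitor shown, with compound 2 nearest and compound 1 furthest away.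

Compound 4 `O=C(Nc1ccccc1O)C1CCc2ccccc2N1C(=O)c1ccccc1` is the next step from compound 3. The change is hydroxy in place of trifluoromethyl on an aromatic carbon. Among the measured compounds shown here, the only measured single step, a 2.6-fold lower number from compound 1 to compound 2 (0.41 log units; beyond the scatter), concerns a different part of the molecule and so gives no direct guide to exchanging trifluoromethyl for hydroxy. What can be said is that compound 2, which also carries the hydroxy group, gives 19600 nM, a higher number than compound 3.

The step from compound 3 to compound 4 is therefore expected to be a modest rise, a 2.2-fold higher number from compound 3 to compound 4 (0.35 log units; beyond the scatter), toward the region of compound 2. Compound 4 is estimated at 18000 nM, within a range from 7000 nM to 50000 nM.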

Compound 4, concentration for 50% growth inhibition: 4260 nM
For compound 4 the middle estimate is 4.2-fold (0.63 log units) above the measured one; the whole stated range lies above it.
By their numbers in this assay, from the lowest: compounds 4 and 3 (each within the scatter of the next); then compound 2; then compound 1.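

In this assay, hydroxy in place of trifluoromethyl on this aromatic carbon, ortho to a large group, gives a 1.9-fold lower number from compound 3 to compound 4 (0.28 log units; within the scatter), so the two groups cannot be told apart here, even though hydroxy brings a hydrogen-bond donor and trifluoromethyl brings none. With hydroxy kept in place, the acyl end of the molecule does separate the compounds: hydrogen in place of chloro gives a 4.6-fold lower number from compound 2 to compound 4 (0.66 log units; beyond the scatter) and phenyl in place of methyl on the carbonyl carbon gives a 12-fold lower number from compound 1 to compound 4 (1.08 log units; beyond the scatter), which shows that a plain benzoyl group is tolerated at least as well as the other two. Nothing measured here explains any of these steps.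

From the compounds shown here alone, whether an amine or a carboxylic acid on the same aromatic carbon would also leave the number unchanged remains open. So does the outcome of a longer chain in place of phenyl on the carbonyl carbon.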